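The source may report more compounds than this note shows. Statements on the series, on what has been measured and on what is new or still open speak of the compounds shown alone.

Series notes, step from compound 2 to compound 3.

Compound 1 `CCN(Cc1ccc(OC)cc1)Cc1c(O)ccc2c(=O)cc(C)oc12` is the reference point. In a functional assay on A-431 cells (Homo sapiens) for inhibition, read by sulforhodamine B assay, with a stated time of 72 h (a lower number here means a stronger inhibitor, a higher number a weaker inhibitor), compound 1 gives 42 ug/mL. Compound 2 `COc1ccc(CN(Cc2ccc([N+](=O)[O-])cc2)Cc2c(O)ccc3c(=O)cc(C)oc23)cc1` carries 4-nitrophenyl in place of methyl on a saturated chain carbon bound to an amine nitrogen. For compound 2 this assay reports only a limit, > 100 ug/mL, so its position is known only as the limit of > 100 ug/mL in this assay, at which 1 of the 2 values shown sits. Within the data shown here, the one measured step at this position, an at least 2.3-fold higher number from compound 1 to compound 2 (0.37 log units; beyond the scatter), runs toward weaker inhibition, and its true size is open because of the limit of > 100 ug/mL in this assay, at which 1 of the 2 values shown sits.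

Compound 3 `COc1ccc(CN(Cc2ccc3ccccc3c2)Cc2c(O)ccc3c(=O)cc(C)oc23)cc1` differs from compound 2 by naphthalen-2-yl in place of 4-nitrophenyl on a saturated chain carbon bound to an amine nitrogen. Among the measured compounds shown here, no measured pair shows this exchange; the only step that touches the same position is an at least 2.3-fold higher number from compound 1 to compound 2 (0.37 log units; beyond the scatter), which concerns a different incoming group. The expectation for compound 3 therefore rests on little more than the limit of compound 2, and a wide range is taken. The change from compound 2 to compound 3 is expected as an at least 1.1-fold lower number from compound 2 to compound 3 (0.04 log units; that floor lies within the scatter). In this assay compound 3 is estimated at 90 ug/mL, between 35 ug/mL and 250 ug/mL.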

Compound 3, half-maximal inhibitory concentration: 16.4 ug/mL
Compound 3: the middle estimate sits 5.5-fold (0.74 log units) above what was measured, outside the stated range (below it).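

In this assay, the place on a saturated chain carbon bound to an amine nitrogen now shows movement in both directions, and not only the loss seen earlier: a 2.6-fold lower number from compound 1 to compound 3 (0.41 log units; beyond the scatter) with naphthalen-2-yl in place of methyl, against an at least 2.3-fold higher number from compound 1 to compound 2 (0.37 log units; beyond the scatter) with 4-nitrophenyl in place of methyl. An aromatic group at this place therefore does not by itself go with weaker inhibition, as the exchange of 4-nitrophenyl for naphthalen-2-yl gives an at least 6.0-fold lower number from compound 2 to compound 3 (0.78 log units; beyond the scatter), and compound 3 is the only one of the three with a step toward stronger inhibition from compound 1. The size of that exchange remains a floor and not a measured gap because the value of compound 2 is a limit of the assay: the limit of > 100 ug/mL in this assay, at which 1 of the 3 values shown sits.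

The compounds shown leave open whether the change follows from the second six-membered aromatic ring of naphthalen-2-yl or from the departure of the nitro group, a distinction that a plain phenyl group at this place would help to draw. Also open, on these data alone, is whether the attachment point matters, which naphthalen-1-yl would address, and whether the 4-methoxybenzyl group on the same amine nitrogen contributes to the result.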